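From tert-butoxycarbonyl to (quinolin-5-yl)methyl on one nitrogen

The source may report more compounds than this note shows. Statements on the series, on what has been measured and on what is new or still open speak of the compounds shown alone.

Going by the values given here, in a functional assay on U-87MG ATCC cells (Homo sapiens) for antiproliferative activity, with a stated time of 3 days (on this read-out higher numbers stand for an effect only at larger amounts of compound and lower numbers for an effect already at smaller amounts), compound 1 (`CC(C)(C)OC(=O)N(Cc1ccc(C(F)(F)F)cc1)Cc1ccc(O)c2ncccc12`) gives 2 uM as the only true number so far. Compound 2 (`CC(C)(C)OC(=O)N(Cc1cccc(C(F)(F)F)c1)Cc1ccc(O)c2ncccc12`) sits at > 10 uM which is a limit and not a number. Among the compounds with values here, the one measured step is an at least 5.0-fold higher number from compound 1 to compound 2 (0.69 log units; beyond the scatter) and it lies in a different part of the molecule from the change considered here. Compound 3 (`Oc1ccc(CN(Cc2ccc(C(F)(F)F)cc2)Cc2cccc3ncccc23)c2cccnc12`) carries (quinolin-5-yl)methyl in place of tert-butoxycarbonyl on an amine nitrogen. Within the data shown here, no measured step tests this swap, so neither its size nor its direction can be read from the data, and the estimate stays anchored on compound 1 at 2 uM with a wide margin. The expected step is a 1.5-fold higher number from compound 1 to compound 3 (0.18 log units; within the scatter) and so nothing clearly beyond the scatter. Compound 3 is estimated at 3 uM with an expected range from 1 uM to 10 uM around that middle.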

Compound 3, concentration for half-maximal effect: > 10 uM
Compound 3: only a limit was reported; the forecaster's own chance of this, stated with the estimate: 25%; at least 3.3-fold (0.52 log units) between middle value and limit.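

In this assay, the group on this amine nitrogen turns out to matter: (quinolin-5-yl)methyl in place of tert-butoxycarbonyl gives an at least 5.0-fold higher number from compound 1 to compound 3 (0.69 log units; beyond the scatter). Going by these compounds alone, the earlier step changed only the 4-(trifluoromethyl)phenyl part, so this is the first measured sign that activity in this small set also depends on the group at this second place. Compound 3 gives > 10 uM, a limit and not a number, and the full size of the step stays unknown because the readings stop there: the limit of > 10 uM in this assay, at which 2 of the 3 values shown sit.

The compounds shown leave open whether a much smaller group on this nitrogen, such as acetyl or a plain methyl, would keep the activity of compound 1. They also leave open how a simple benzyl group would compare with (quinolin-5-yl)methyl at this place.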